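The compounds below may be only part of what the source reports. "The series", "measured", "known", "first", "only" and "open" are said of these compounds alone.

Compound 1 `N#CCNC(=O)[C@@H]1C[C@@H](S(=O)(=O)c2ccccc2C(F)(F)F)C[C@H]1C(=O)N1CCOCC1` — in an assay on isolated protein for inhibition of cathepsin S (Homo sapiens), read by fluorescence, with a stated time of 20 min (on this read-out lower numbers stand for stronger inhibition and higher numbers for weaker inhibition), compound 1 gives 0.9 nM.
Compound 2 `N#CC1(NC(=O)[C@@H]2C[C@@H](S(=O)(=O)c3ccccc3)C[C@H]2C(=O)N2CCOCC2)CCC1` — in this assay compound 2 gives 4 nM.
Compound 3 `N#CC1(NC(=O)[C@@H]2C[C@@H](S(=O)(=O)c3ccccc3)C[C@H]2C(=O)N2CC3CCC(C2)O3)CC1` — in this assay compound 3 gives 1 nM.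

Compound 3 stands second highest of the three numbers. Its nearest neighbour is compound 1, whose number is within the scatter of that of compound 3; compound 2 shows a higher number, and that gap lies beyond the scatter. Compound 4 `CN1CCN(C(=O)[C@@H]2C[C@H](S(=O)(=O)c3ccccc3)C[C@H]2C(=O)NC2(C#N)CC2)CC1` differs from compound 3 in one place: a group of 7 heavy atoms (5 carbon, 2 nitrogen; one six-membered non-aromatic ring with 2 hetero atoms) in place of a group of 8 heavy atoms (6 carbon, 1 nitrogen, 1 oxygen; one five-membered non-aromatic ring with 1 hetero atom, one six-membered non-aromatic ring with 2 hetero atoms), on a carbonyl carbon. For the measured compounds named here, no step between measured compounds covers such a change, so the expectation rests on the spread among compounds 1, 2 and 3 alone. The step from compound 3 to compound 4 in this assay is expected to be small, a 2.0-fold higher number from compound 3 to compound 4 (0.30 log units; within the scatter), and possibly no change beyond the scatter. Compound 4 is estimated at 2 nM, within a range from 0.6 nM to 7 nM.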

Compound 4, half-maximal inhibitory concentration: 2 nM
The estimate for compound 4 equals the measured number at the digits printed, and the stated range covers the measured number.
By their numbers in this assay, from the lowest: compounds 1, 3, 4 and 2 (each within the scatter of the next, the first and the last beyond it).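

In this assay, replacing the two-ring group on the carbonyl carbon with 4-methylpiperazin-1-yl gives a 2.0-fold higher number from compound 3 to compound 4 (0.30 log units; within the scatter). At this position, then, a single six-membered ring holding two nitrogens takes the place of the two-ring group holding one nitrogen and one oxygen, with no change beyond the scatter. Nothing measured here offers an explanation for this result.

The compounds shown leave open how an unsubstituted piperazine or an open-chain amine such as dimethylamine would read at this carbonyl carbon. They also leave open whether a carboxylic acid on that ring would fit the same range.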